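A few compounds are considered here, and "the series" means these few. Any claim that something is new, unique, unknown or untested is made for them only; others in the source may bear on it.

Among the compounds with values here, only two compounds have been through a physicochemical assay for solubility (a higher number here means a more soluble compound, a lower number a less soluble compound), so far, and neither gave an exact number. Compound 1 `COC(=O)c1ccc(C(=O)/C(=C\c2ccc(F)c([N+](=O)[O-])c2)SCc2ccc(Br)cc2)cc1` reads < 1000 ug/mL, which is a limit of the assay and not a number. Compound 2 `O=C(O)c1ccc(C(=O)/C(=C\c2ccc(F)cc2[N+](=O)[O-])SCc2ccc(Br)cc2)cc1` reads < 1000 ug/mL, which is also a limit. Compound 2 therefore has no exact place on the scale, only (the limit of < 1000 ug/mL in this assay, at which 2 of the 2 values shown sit), and no order can be drawn between the two compounds.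

Compound 3 `O=C(O)c1ccc(C(=O)/C(=C\c2ccc(Br)c([N+](=O)[O-])c2)SCc2ccc(Br)cc2)cc1` has not yet been measured. It differs from compound 2 in one place, on a double-bonded chain carbon bound to a double-bonded chain carbon, where 4-bromo-3-nitrophenyl stands in place of 4-fluoro-2-nitrophenyl: 4-bromo-3-nitrophenyl in place of 4-fluoro-2-nitrophenyl on a double-bonded chain carbon bound to a double-bonded chain carbon. Within the data shown here, no measured pair of compounds shows what a swap of this kind does, so no change beyond the usual scatter is expected, in either direction. The most likely report for compound 3 is another limit. The expected change is a step that the limit leaves unreadable from compound 2 to compound 3, which is only an estimate. If a number does appear, the estimate for compound 3 is 500 ug/mL, with a range from 80 ug/mL to 1000 ug/mL.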

Compound 3, solubility: < 1000 ug/mL
Compound 3: only a limit was reported; the forecaster's own chance of this, stated with the estimate: 85%; the middle value is on the limit's open side.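

In this assay, within the data shown here, compound 2 and compound 3 each gave a limit and not a number, so no step between compound 2 and compound 3 can be read. Still open, going by these compounds, is where any of the compounds truly sits on the scale, and whether 4-bromo-3-nitrophenyl in place of 4-fluoro-2-nitrophenyl changes the reading, because all share one result: the limit of < 1000 ug/mL in this assay, at which 3 of the 3 values shown sit.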